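The source may hold more compounds than are shown below. What is called first, only, known or untested is meant among the compounds shown, and "the series" means these compounds.

Measured in an ADME assay on Vero cells (Chlorocebus sabaeus) for cytotoxicity, read by MTT assay; on this read-out higher numbers stand for weaker inhibition and lower numbers for stronger inhibition:
- Compound 1 `C=CCOc1cc(OC)c(C(=O)/C=C/c2cccc(OC)c2)c(OCC=C)c1`: 142000 nM
- Compound 2 `C=CCOc1cc(OC)c(C(=O)/C=C/c2ccccc2Br)c(OCC=C)c1`: 13900 nM

Within the data shown here, compound 2 has the lower of the two numbers, and compound 1 is its only neighbour. The next compound, compound 3 `C=CCOc1cc(OC)c(C(=O)/C=C/c2ccccn2)c(OCC=C)c1`, differs from compound 2 as follows: pyridin-2-yl in place of 2-bromophenyl on a double-bonded chain carbon bound to a double-bonded chain carbon. Among the measured compounds shown here, only one measured step bears on this change: a 10-fold lower number from compound 1 to compound 2 (1.01 log units; beyond the scatter). It sits at the same place, is large and lies beyond the scatter. For the measured compounds named here, no measured compound carries pyridin-2-yl, so this step is only an indirect guide. Compound 3 gives up the 2-bromophenyl of compound 2 at 13900 nM, so a move back up towards the number of compound 1 is expected in this assay. The expected change is a 3.6-fold higher number from compound 2 to compound 3 (0.56 log units; beyond the scatter). For compound 3 the estimate is 50000 nM, with an expected range of 15000 nM to 150000 nM.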

Compound 3, half-maximal inhibitory concentration: 2800 nM
For compound 3 the middle estimate is 18-fold (1.25 log units) above the measured one, and the stated range ends above it.
By their numbers in this assay, from the lowest: compound 3; then compound 2; then compound 1.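

In this assay, pyridin-2-yl in place of 2-bromophenyl on a double-bonded chain carbon bound to a double-bonded chain carbon gives a 5.0-fold lower number from compound 2 to compound 3 (0.70 log units; beyond the scatter), while the change from 3-methoxyphenyl to pyridin-2-yl at the same place gives a 51-fold lower number from compound 1 to compound 3 (1.71 log units; beyond the scatter). Bromine is therefore not required for a low number at this place: a six-membered aromatic ring with a hetero atom and no halogen gives the lowest number of the three compounds. No measurement available here accounts for this order.

Going by these compounds, whether the lower number goes with the ring nitrogen or simply with the loss of bromine remains open. Unsubstituted phenyl and pyridin-4-yl at this place would help separate those two readings.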